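Hexyl on the Amine of a Long-Chain Amino Alcohol

A few compounds are considered here, and "the series" means these few. Any claim that something is new, unique, unknown or untested is made for them only; others in the source may bear on it.

The series consists of long-chain compounds studied in an ADME assay on cells (Splenocyte, Mus musculus, strain BALB/c) for cytotoxicity, read by MTT assay, tested at 1 ug/mL; a lower number here means a weaker effect, a higher number a stronger effect of the compound at the concentration tested. Compound 1, `CCCCCCCCCCCCCCC(NC(=O)OC(C)(C)C)C(=O)O`, has no number in this assay, since no result was reported for it: compound 1 stands at "not determined" (no result reported). Compound 2, `CCCCCCCCCCCCCCC(N)CO`, gives 15.1% in this assay. Compound 3, `CCCCCCCCCCCCCCC(COCc1ccccc1)N(CC)CC`, gives 14.1% in this assay. Within the data shown here, these are the only two numbers at hand, and the gap between compound 2 and compound 3 lies within the scatter of repeated measurements, so the two stand together and neither can be set above the other.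

Compound 4, `CCCCCCCCCCCCCCC(CO)NCCCCCC`, has not yet been measured. It differs from compound 2 in a single place: hexyl in place of hydrogen on an amine nitrogen. Among the measured compounds shown here, no step between two measured compounds is available to size this change, and the two numbers reported so far are indistinguishable within the scatter. Compound 4 is therefore expected to give a result close to that of compound 2, with the step of a number 1.9 percentage points higher from compound 2 to compound 4 (within the scatter) expected to fall within the usual scatter rather than beyond it. Compound 4 is estimated at 17%, with a range from 7% to 30%.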

Compound 4, a percentage reported as activity, at one concentration (the size of the read-out at that concentration, not a potency): 5%
For compound 4 the middle estimate is 12 percentage points above the measured one; the measured number lies below the stated range.
By their numbers in this assay, from the lowest: compounds 4, 3 and 2 (each within the scatter of the next, the first and the last beyond it).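

In this assay, hexyl in place of hydrogen on an amine nitrogen gives a number 10.1 percentage points lower from compound 2 to compound 4 (beyond the scatter). Among these compounds, this is the first step that can be sized, and it shows that this position does not tolerate the change without consequence: a chain of six carbons, with no ring, lowers the effect at the concentration tested rather than leaving it unchanged. Nothing on hand speaks to why the read-out moves in this way.

The compounds shown leave open whether a shorter chain such as methyl on the same nitrogen would give a smaller step, or a longer one such as decyl a larger step, so this single step sets no trend with chain length. They also leave open whether a benzyl or an acetyl group at this nitrogen would behave as hexyl does.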